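Nitro analogue of the series: expected lipophilicity

The compounds below may be only part of what the source reports. "The series", "measured", "known", "first", "only" and "open" are said of these compounds alone.

The series shares one core carrying an oxime and a three-carbon chain on the charged ring. Compound 2 `CCN(CC)CCCn1cc[n+](C)c1/C=N/O` carries a diethylamino group at the end of that chain and gives -2.78 in a physicochemical assay for lipophilicity (on this read-out lower numbers stand for lower lipophilicity and higher numbers for higher lipophilicity), the lowest of the three numbers obtained so far. Compound 3 `CCN(CCCn1cc[n+](C)c1/C=N/O)S(C)(=O)=O` gives -2.69 in this assay, and compound 1 `C[n+]1ccn(COCCCS(C)(=O)=O)c1/C=N/O` gives -2.5; both lie within the scatter of compound 2, so no order among the three can be claimed.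

The next member, compound 4 `C[n+]1ccn(CCCC(C)(C)[N+](=O)[O-])c1/C=N/O`, differs from compound 2 in one place: 1-methyl-1-nitroethyl in place of diethylamino on a saturated chain carbon, three bonds along the chain from an aromatic nitrogen. For the measured compounds named here, the only single-point step known so far is a number 0.09 log units higher from compound 2 to compound 3 (within the scatter), where methylsulfonyl replaced ethyl on the amine nitrogen with no shift beyond the scatter. Compound 1 differs from compound 2 in more than one place, so its value shows only that an ether-linked methylsulfonyl chain stays close to the others. Neither step probes an exchange of the amine itself, so the bearing on compound 4 is indirect.

On this basis a small upward step is expected, a number 0.38 log units higher from compound 2 to compound 4 (beyond the scatter), and compound 4 is estimated at -2.4, within -2.9 to -1.9.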

Compound 4, distribution coefficient: -2.18
Compound 4: middle estimate off by 0.22 log units, on the low side; measured number inside the range.
By their numbers in this assay, from the lowest: compounds 2, 3 and 1 (each within the scatter of the next); then compound 4.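

For the compounds shown here, exchanging the whole amine at this position gives the first step that clears the scatter in this assay (a number 0.60 log units higher from compound 2 to compound 4 (beyond the scatter)), whereas the change on the amine nitrogen stayed within it (a number 0.09 log units higher from compound 2 to compound 3 (within the scatter)). The read-out at this chain end therefore responds to 1-methyl-1-nitroethyl in place of diethylamino, on a saturated chain carbon, three bonds along the chain from an aromatic nitrogen, and this exchange is not interchangeable with methylsulfonyl in place of ethyl. The entering group has 6 heavy atoms and 2 hydrogen-bond acceptors against 5 heavy atoms and 1 hydrogen-bond acceptor in the leaving group, but no measurement here bears on what lies behind the step.

The compounds shown leave open whether the step goes with the nitro group or with the branched carbon that carries it, and a tert-butyl group or a carboxylic acid at the same place would separate the two. Also open, as far as these compounds go, is whether a step of this size holds on a longer chain, as the whole reading rests on a single pair.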